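The source may report more compounds than this note shows. Statements on the series, on what has been measured and on what is new or still open speak of the compounds shown alone.

Compound 1 `CC(C)CN(c1ccc(N(C)C)cc1)S(=O)(=O)c1ccc2c(c1)C(O)CC(C1CCOCC1)O2` is the second highest of three compounds in a physicochemical assay for lipophilicity, at pH 7.4 (a higher number here means a more lipophilic compound, a lower number a more polar compound), giving 3.51. Compound 2 `CCc1ccc(NS(=O)(=O)c2ccc3c(c2)C(O)CC(C2CCOCC2)O3)cc1` gives 2.59 and compound 3 `CCc1ccc(N(Cc2ccccc2)S(=O)(=O)c2ccc3c(c2)C(O)CC(C2CCOCC2)O3)cc1` gives 4.68. Within the data shown here, the only step between measured compounds, a number 2.09 log units higher from compound 2 to compound 3 (beyond the scatter), concerns an addition on the sulfonamide nitrogen rather than a swap of one aromatic group for another, so no measured step bears directly on the change to compound 4 `CC(C)CN(c1ccc(F)cc1F)S(=O)(=O)c1ccc2c(c1)C(O)CC(C1CCOCC1)O2`. That change is 2,4-difluorophenyl in place of 4-(dimethylamino)phenyl on a sulfonamide nitrogen. The group that leaves and the group that enters are both six-membered aromatic rings of similar size, so compound 4 is expected to differ from compound 1 by a small step, a number 0.09 log units higher from compound 1 to compound 4 (within the scatter), within the scatter. Compound 4 is estimated at 3.6, between 3.1 and 4.1.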

Compound 4, distribution coefficient: 3.53
The estimate for compound 4 lay 0.07 log units above the measured number; measured number inside the range.
By their numbers in this assay, from the lowest: compound 2; then compounds 1 and 4 (each within the scatter of the next); then compound 3.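

In this assay, 2,4-difluorophenyl in place of 4-(dimethylamino)phenyl on the sulfonamide nitrogen gives a number 0.02 log units higher from compound 1 to compound 4 (within the scatter). The earlier compounds shown here showed only an addition on such a nitrogen, benzyl in place of hydrogen, with a number 2.09 log units higher from compound 2 to compound 3 (beyond the scatter); here, one aromatic group exchanged for another leaves no difference that can be told from the scatter. Nothing measured explains why these two groups give such similar numbers.

On these data alone, whether a phenyl ring carrying a carboxylic acid would also match compound 1 remains open. So does whether this exchange would give the same result with benzyl in place of the saturated chain on that nitrogen.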